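From 2-methylphenyl to 3-fluorophenyl in compound 4

The source may hold more compounds than are shown below. What is called first, only, known or untested is meant among the compounds shown, and "the series" means these compounds.

Compound 1 `CCNC(=O)c1cc(Oc2ccc(NC(=O)c3nn(-c4cccc(F)c4)c(=O)cc3C)cc2)ccn1` gives 7410 nM
Compound 2 `CNC(=O)c1cc(Oc2ccc(NC(=O)c3nn(-c4ccccc4Cl)c(=O)cc3C)cc2F)ccn1` gives 11800 nM
Compound 3 `CCCNC(=O)c1cc(Oc2ccc(NC(=O)c3nn(-c4ccccc4C)c(=O)cc3C)cc2F)ccn1` gives 25700 nM

In a functional assay on A549 cells (Homo sapiens) for antiproliferative activity, read by MTT assay, with a stated time of 72 h (a lower number here means a stronger inhibitor, a higher number a weaker inhibitor), compound 3 stands highest of the three at 25700 nM and is the weakest inhibitor among them. Compound 2 lies nearest and compound 1 furthest, both beyond the scatter. Compound 4 `CCCNC(=O)c1cc(Oc2ccc(NC(=O)c3nn(-c4cccc(F)c4)c(=O)cc3C)cc2F)ccn1` carries 3-fluorophenyl in place of 2-methylphenyl on an aromatic nitrogen. Among the measured compounds shown here, no measured pair isolates this change. Compound 1 also carries 3-fluorophenyl and gives 7410 nM in this assay, though it differs elsewhere too, so a moderate move toward a lower number is expected. The expected change is a 2.3-fold lower number from compound 3 to compound 4 (0.37 log units; beyond the scatter) and would mean a stronger inhibitor. Compound 4 is estimated at 11000 nM (range 4500 nM to 27000 nM).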

Compound 4, half-maximal inhibitory concentration: 7020 nM
For compound 4 the middle estimate is 1.6-fold (0.20 log units) above the measured one, and the stated range covers the measured number.
By their numbers in this assay, from the lowest: compounds 4, 1 and 2 (each within the scatter of the next); then compound 3.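

In this assay, the change to 3-fluorophenyl in place of 2-methylphenyl on the aromatic nitrogen gives a 3.7-fold lower number from compound 3 to compound 4 (0.56 log units; beyond the scatter) with the rest of the structure unchanged. Among the compounds shown here, this is the first comparison here that isolates this position, and it shows that this change alone moves the number beyond the scatter, by a modest step. Nothing shown here accounts for the step.

Going by these compounds, whether the shift comes from losing the 2-methylphenyl group or from gaining 3-fluorophenyl stays open. So does how an unsubstituted phenyl or a pyridine ring would read on this nitrogen.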